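Losing One Methyl on the Chain of Compound 1

This account rests on a few compounds, and the source may have more. Where it says the series, first, only, none or still open, it means among the compounds named here.

Compound 1 `CC(c1nccs1)C(C#N)(C#N)CCC(F)=C(F)F` gives > 120000 nM in a functional assay on SH-SY5Y cells (Homo sapiens) for cytotoxicity, read by MTT assay, with a stated time of 48 h; on this read-out higher numbers stand for weaker inhibition and lower numbers for stronger inhibition; this is a limit of the assay, not a number.
Compound 2 `FC(F)=C(F)CCSc1nc2ccccc2[nH]1` gives > 120000 nM in this assay; this too is a limit.
Compound 3 `[O-][S+](CCC(F)=C(F)F)c1nc2ccccc2s1` gives 7000 nM in this assay.

Among these values compound 1 stands at the limit of > 120000 nM in this assay, at which 2 of the 3 values shown sit, so only a limit is known for it. Compound 4 `N#CC(C#N)(CCC(F)=C(F)F)Cc1nccs1` differs from compound 1 by a single change: hydrogen in place of methyl on a saturated chain carbon bound to an aromatic carbon and a saturated chain carbon. Among the compounds with values here, no pair of measured compounds differing in one place is available, so nothing shows how far such a small change moves the read-out. Because compound 1 already sits at the limit of > 120000 nM in this assay, at which 2 of the 3 values shown sit, the step that the limit leaves unreadable from compound 1 to compound 4 is expected to be none beyond the scatter, and the result will most likely again be a limit. Compound 4 is therefore estimated at 150000 nM, with a range from 40000 nM to 600000 nM.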

Compound 4, half-maximal inhibitory concentration: > 120000 nM
Compound 4 gave a limit, no number; the forecaster's own chance of this, stated with the estimate: 75%; the middle value does not contradict the limit.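

No step can be read from compound 1 to compound 4, because both results are limits rather than numbers: the limit of > 120000 nM in this assay, at which 3 of the 4 values shown sit. The compounds shown leave open how far hydrogen in place of methyl moves the read-out.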